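The source may hold more compounds than are shown below. What is called first, only, known or untested is meant among the compounds shown, and "the series" means these compounds.

Of the compounds shown here, three of one series have been measured in an ADME assay on the whole organism for inhibition, with Triticum aestivum as the target, with a stated time of 5 days; a lower number here means a stronger inhibitor, a higher number a weaker inhibitor. Compound 3 `O=C1C(c2ccccc2)Oc2c(Cl)cccc2N1O` gives 263000 nM, and compound 1 `CCC1Oc2c(Cl)cccc2N(O)C1=O` gives 345000 nM. Among the measured compounds shown here, the one change between them, (ethyl in place of phenyl on a saturated ring carbon), made a step of a 1.3-fold higher number from compound 3 to compound 1 (0.12 log units; within the scatter). Compound 2 `O=C1C(c2ccccc2)Oc2ccc(F)cc2N1O` gives 641000 nM in this assay, the highest of the three numbers, though its gap to compound 1 lies within the scatter and only its gap to compound 3 lies beyond it. How the core of compound 2 differs from the core of compound 3 is not broken down here.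

Compound 4 `CCC1Oc2ccc(F)cc2N(O)C1=O` has not yet been measured. For the measured compounds named here, it differs from compound 2 by ethyl in place of phenyl on a saturated ring carbon, which is the same change as the one from compound 3 to compound 1, the place being described in the same words both times. For compound 4 an expected step of a 1.2-fold higher number from compound 2 to compound 4 (0.10 log units; within the scatter) is taken because the same change earlier made a step of a 1.3-fold higher number from compound 3 to compound 1 (0.12 log units; within the scatter), and that step lay within the scatter. On that basis compound 4 is expected to give about 800000 nM in this assay, with a likely range from 350000 nM to 2000000 nM.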

Compound 4, half-maximal inhibitory concentration: 63100 nM
Beside the measured number, compound 4's estimate is 13-fold (1.10 log units) above it; the whole stated range lies above it.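

In this assay, ethyl in place of phenyl on a saturated ring carbon gave a large step, a 10-fold lower number from compound 2 to compound 4 (1.01 log units; beyond the scatter), and this did not match what the same change did on the other core: the same change on two cores in this assay, a 1.3-fold higher number (0.12 log units; within the scatter) from compound 3 to compound 1 and a 10-fold lower number (1.01 log units; beyond the scatter) from compound 2 to compound 4, 13-fold (1.12 log units) apart, beyond the scatter of two such steps

The size and direction of the step on one core therefore gave no reliable guide to the step on the other in this series, so this change cannot simply be carried between these two cores. The result does not show why the two cores behave differently, and with a single pair on each core it cannot tell how the change would behave on any further core.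

The compounds shown leave open whether methyl, a longer chain such as butyl, or a benzyl group on that saturated ring carbon would also differ between the two cores. They also leave open how the same change would behave on a core carrying a methoxy group or an amine in place of the chlorine or fluorine.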